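Removing the methyl from the pendant aryl group of compound 3

The source may report more compounds than this note shows. Statements on the series, on what has been measured and on what is new or still open speak of the compounds shown alone.

Measured so far:
compound 1 `Cn1c(-c2ccccc2Cl)nc2c(NC3CCCC3)ncnc21` — 720 nM
compound 2 `Cn1c(-c2cccnc2)nc2c(NC3CCCC3)ncnc21` — 11000 nM
compound 3 `Cc1ccccc1-c1nc2c(NC3CCCC3)ncnc2n1C` — 3000 nM

In an assay on CHO cells for displacement of a labelled ligand from adenosine receptor A3 (Homo sapiens), read by scintillation counting, with a stated time of 3 h (a lower number here means a stronger inhibitor, a higher number a weaker inhibitor), compound 3 stands second highest of the three; the nearest number is compound 2, the furthest compound 1, with a 4.2-fold higher number from compound 1 to compound 3 (0.62 log units; beyond the scatter) and a 3.7-fold lower number from compound 2 to compound 3 (0.56 log units; beyond the scatter) both beyond the scatter. Compound 4 `Cn1c(-c2ccccc2)nc2c(NC3CCCC3)ncnc21` differs from compound 3 by hydrogen in place of methyl on an aromatic carbon. Among the compounds with values here, no measured step removes this methyl outright; the nearest guide is the step of a 4.2-fold higher number from compound 1 to compound 3 (0.62 log units; beyond the scatter), a change of the group at the same place, and compound 2 shows that a different aryl costs far more. A step beyond the scatter, in either direction, is therefore plausible but not supported by a direct precedent. Compound 4 is expected near 4000 nM, range 1200 nM to 13000 nM, meaning an estimated step of a 1.3-fold higher number from compound 3 to compound 4 (0.12 log units; within the scatter).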

Compound 4, inhibition constant: 846 nM
The estimate for compound 4 lay 4.7-fold (0.67 log units) above the measured number; the measured number lies below the stated range.
By their numbers in this assay, from the lowest: compounds 1 and 4 (each within the scatter of the next); then compound 3; then compound 2.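

In this assay, removing the methyl from the aromatic carbon ortho to a large group gives a direct reading at this place (a 3.5-fold lower number from compound 3 to compound 4 (0.55 log units; beyond the scatter)), so this methyl is not tolerated as well as hydrogen. Hydrogen and chloro cannot be told apart here (a 1.2-fold higher number from compound 1 to compound 4 (0.07 log units; within the scatter)), while phenyl retains a large advantage over pyridin-3-yl (a 13-fold lower number from compound 2 to compound 4 (1.11 log units; beyond the scatter)). No supporting measurement explains these differences. On these data alone, whether methoxy or an amine at this place would behave like methyl or like hydrogen and chloro remains open.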